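The source may hold more compounds than are shown below. What is called first, only, known or untested is meant among the compounds shown, and "the series" means these compounds.

Measured compounds in a physicochemical assay for lipophilicity, at pH 7.4; on this read-out lower numbers stand for lower lipophilicity and higher numbers for higher lipophilicity:
compound 1, `C[C@H]1C(=O)N(C)C=Cc2ccccc21`: 4.3
compound 2, `COc1ccc2c(c1)C=CN(C)C(=O)[C@@H]2C`: 4.3
compound 3, `C[C@H]1C(=O)N(C)C=Cc2cc(CC3CCOCC3)ccc21`: 5.4

Compound 1 stands level with compound 2 at the digits given, and together these two are the lowest of the three numbers; the step of no change at the digits printed from compound 1 to compound 2 (within the scatter) lies within the scatter. Compound 3 is furthest from compound 1, the step of a number 1.10 log units higher from compound 1 to compound 3 (beyond the scatter) being large, as is a number 1.10 log units higher from compound 2 to compound 3 (beyond the scatter).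

Compound 4, `CCS(=O)(=O)c1ccc2c(c1)C=CN(C)C(=O)[C@@H]2C`, has not yet been measured in this assay. Relative to compound 1 the change is ethylsulfonyl in place of hydrogen on an aromatic carbon. For the measured compounds named here, none of the measured steps introduces an ethylsulfonyl group, so no step bears on this change directly. The nearest comparison is the methoxy step from compound 1 to compound 2, which gave no change within the scatter, while the (oxan-4-yl)methyl step from compound 1 to compound 3 went the other way. The account therefore expects compound 4 to fall below compound 1 by a moderate step, a number 1.00 log units lower from compound 1 to compound 4 (beyond the scatter), though with wide uncertainty given that nothing measured resembles this group. The estimate for compound 4 is 3.3, expected to lie between 2.7 and 3.9.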

Compound 4, distribution coefficient: 3.1
For compound 4 the middle estimate is 0.20 log units above the measured one; the measured number falls inside the stated range.
By their numbers in this assay, from the lowest: compound 4; then compounds 1 and 2 (each within the scatter of the next); then compound 3.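

In this assay, for the compounds shown here, ethylsulfonyl is the first group at this aromatic carbon to bring the number down from that of the hydrogen-bearing compound (a number 1.20 log units lower from compound 1 to compound 4 (beyond the scatter)), whereas methoxy left it within the scatter and (oxan-4-yl)methyl raised it, so across these compounds the number can move in either direction from hydrogen, depending on the group that enters. The same direction holds when ethylsulfonyl replaces another substituent at this position rather than hydrogen, both for methoxy (a number 1.20 log units lower from compound 2 to compound 4 (beyond the scatter)) and for (oxan-4-yl)methyl (a number 2.30 log units lower from compound 3 to compound 4 (beyond the scatter)), the latter being the widest step among the listed compounds. No available evidence explains the drop seen with this group.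

As far as these compounds go, whether the sulfonyl unit or its ethyl chain sets the size of the step remains open, and a methylsulfonyl group, a longer alkylsulfonyl chain or a sulfonamide on the same aromatic carbon would help to separate the two. From the compounds shown here alone, it also remains open how an amine or a carboxylic acid would behave at this position, and whether ethylsulfonyl would give a similar step on another carbon of the same aromatic ring.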